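Does a larger aromatic group shift the value?

A few compounds are considered here, and "the series" means these few. Any claim that something is new, unique, unknown or untested is made for them only; others in the source may bear on it.

- Compound 1 `O=C1/C(=C\c2ccccc2)c2c(ncn2COCc2ccccc2)CCN1Cc1ccc(F)cc1` gives 19600 nM
- Compound 2 `Cc1cccc(CN2CCc3ncn(COCc4ccccc4)c3/C(=C/c3ccccc3)C2=O)c1` gives 16100 nM

In a functional assay on A549 cells (Homo sapiens) for inhibition, read by MTT assay, with a stated time of 72 h (on this read-out higher numbers stand for weaker inhibition and lower numbers for stronger inhibition), compound 2 gives 16100 nM, which lies within the usual scatter of compound 1, so the two cannot be told apart. Compound 3 `O=C1/C(=C\c2ccccc2)c2c(ncn2COCc2ccccc2)CCN1Cc1ccc(-c2ccccc2)cc1` brings a new change, (4-phenylphenyl in place of 3-methylphenyl on a saturated chain carbon bound to an amide-type nitrogen in a ring), on a saturated chain carbon bound to an amide-type nitrogen in a ring.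

Among the measured compounds shown here, only one measured step bears on this place: a 1.2-fold lower number from compound 1 to compound 2 (0.09 log units; within the scatter). That swap of 3-methylphenyl for 4-fluorophenyl left the value inside the scatter. However, 4-phenylphenyl is larger than either group tested, so this single step is a thin guide. No clear direction can be drawn from it, and no shift beyond the scatter is expected. The expected change is a 1.1-fold lower number from compound 2 to compound 3 (0.03 log units; within the scatter). For compound 3 the estimate is 15000 nM, with an expected range from 6000 nM to 38000 nM.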

Compound 3, half-maximal inhibitory concentration: 18300 nM
For compound 3 the middle estimate is 1.2-fold (0.09 log units) below the measured one, and the stated range covers the measured number.
By their numbers in this assay, from the lowest: compounds 2, 3 and 1 (each within the scatter of the next).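

In this assay, the step to the larger 4-phenylphenyl gives a 1.1-fold higher number from compound 2 to compound 3 (0.06 log units; within the scatter) and so stays inside the usual scatter, showing that even a group with 2 six-membered aromatic rings on this saturated chain carbon does not separate the compounds. Phenyl in place of fluoro on an aromatic carbon gives a 1.1-fold lower number from compound 1 to compound 3 (0.03 log units; within the scatter) and points the same way, so the earlier small swap and these larger ones all leave the three compounds indistinguishable in this assay. No supporting evidence bears on this result.

Still open, as far as these compounds go, is whether an amine or a carboxylic acid on the aromatic ring at this place would move the value beyond the scatter. A longer chain on the amide-type nitrogen in the ring is equally untested by the compounds shown here.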